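A Fluorophenyl Variant of Compound 3 Awaits Measurement

The source may report more compounds than this note shows. Statements on the series, on what has been measured and on what is new or still open speak of the compounds shown alone.

Three compounds tested in a functional assay on HT-29 cells (Homo sapiens) for cytotoxicity, read by MTT assay, with a stated time of 72 h (on this read-out lower numbers stand for stronger inhibition and higher numbers for weaker inhibition), share one core and differ only in the aryl group on a carbon with a double bond to nitrogen. In this assay compound 1 `COc1ccc(OC)c(/C=N/NC(=O)Nc2ccc(Oc3ccnc(-c4nncn4CCN(C)C)c3)c(F)c2)c1` gives 2070 nM. Compound 2 `CN(C)CCn1cnnc1-c1cc(Oc2ccc(NC(=O)N/N=C/c3cccc(O)c3)cc2F)ccn1` gives 330 nM. Compound 3 `CN(C)CCn1cnnc1-c1cc(Oc2ccc(NC(=O)N/N=C/c3ccccc3O[N+](=O)[O-])cc2F)ccn1` gives 950 nM. Compound 3 therefore holds the second highest of the three numbers: the nearest neighbour is seen in a 2.2-fold lower number from compound 1 to compound 3 (0.34 log units; beyond the scatter), the furthest in a 2.9-fold higher number from compound 2 to compound 3 (0.46 log units; beyond the scatter).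

Compound 4 `CN(C)CCn1cnnc1-c1cc(Oc2ccc(NC(=O)N/N=C/c3ccc(F)cc3)cc2F)ccn1` has not yet been measured. It differs from compound 3 in one place: 4-fluorophenyl in place of 2-(nitrooxy)phenyl on a carbon with a double bond to nitrogen. Every measured step concerns this same position. The largest is a 6.3-fold lower number from compound 1 to compound 2 (0.80 log units; beyond the scatter); the others, a 2.2-fold lower number from compound 1 to compound 3 (0.34 log units; beyond the scatter) and a 2.9-fold higher number from compound 2 to compound 3 (0.46 log units; beyond the scatter), are smaller, yet all three are modest and beyond the scatter. Among the measured compounds shown here, none of the measured compounds carries 4-fluorophenyl, so the direction for compound 4 cannot be read from them, and only a modest movement in either sense is anticipated. Compound 4 is estimated to give 800 nM in this assay, with a range from 250 nM to 2500 nM. That estimate corresponds to an expected 1.2-fold lower number from compound 3 to compound 4 (0.07 log units; within the scatter).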

Compound 4, half-maximal inhibitory concentration: 1370 nM
The estimate for compound 4 lay 1.7-fold (0.23 log units) below the measured number, and the stated range covers the measured number.
By their numbers in this assay, from the lowest: compound 2; then compounds 3, 4 and 1 (each within the scatter of the next, the first and the last beyond it).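

In this assay, 4-fluorophenyl on a carbon with a double bond to nitrogen is not set apart from either of the two groups it can be read against: the change from 2-(nitrooxy)phenyl gives a 1.4-fold higher number from compound 3 to compound 4 (0.16 log units; within the scatter) and the change from 2,5-dimethoxyphenyl gives a 1.5-fold lower number from compound 1 to compound 4 (0.18 log units; within the scatter) in the same read-out. This holds although 4-fluorophenyl has 0 hydrogen-bond acceptors and 7 heavy atoms where 2-(nitrooxy)phenyl has 3 hydrogen-bond acceptors and 10 heavy atoms, so at this position those differences in the count come with no step beyond the scatter (no explanation for this is at hand from any measurement:). The 3-hydroxyphenyl group now stands apart from a third group as well, with a 4.2-fold higher number from compound 2 to compound 4 (0.62 log units; beyond the scatter) on the change to 4-fluorophenyl, and compound 2 keeps a lower number than each of the other three compounds.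

On these data alone, whether the lower number of compound 2 is tied to 3-hydroxyphenyl alone stays open. So does what a phenyl group bearing an amine or a carboxylic acid in place of the hydroxyl would give on this carbon.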